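The source may hold more compounds than are shown below. What is called first, only, known or untested is meant among the compounds shown, and "the series" means these compounds.

For the measured compounds named here, in a functional assay on MGC-803 cells (Homo sapiens) for inhibition, read by CCK-8 assay, with a stated time of 48 h (on this read-out lower numbers stand for stronger inhibition and higher numbers for weaker inhibition), compound 2 `COc1ccc(CN(C(=O)CSC(=S)N2CCc3ccccc32)c2cc(OC)c(OC)c(OC)c2)cc1` gives 8410 nM, the higher of the two numbers so far, while compound 1 `COc1ccc(CN(C(=O)CSC(=S)N2CCN(C(C)=O)CC2)c2cc(OC)c(OC)c(OC)c2)cc1` gives 480 nM. Compound 3 `COc1ccc(CN(C(=O)CSC(=S)N2CCCc3cc(OC)ccc32)c2cc(OC)c(OC)c(OC)c2)cc1` keeps the shared core and changes only the group on a thiocarbonyl carbon: 6-methoxy-1,2,3,4-tetrahydroquinolin-1-yl in place of 2,3-dihydro-1H-indol-1-yl on a thiocarbonyl carbon. Going by the values given here, the one measured step at this place, an 18-fold higher number from compound 1 to compound 2 (1.24 log units; beyond the scatter), is large, so the number responds to the group there, but that step involves a different group and fixes no direction here. A moderate move towards lower numbers is expected, as a 2.8-fold lower number from compound 2 to compound 3 (0.45 log units; beyond the scatter). Compound 3 is estimated at 3000 nM, with an expected range from 600 nM to 12000 nM.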

Compound 3, half-maximal inhibitory concentration: 8210 nM
The estimate for compound 3 lay 2.7-fold (0.44 log units) below the measured number, and the stated range covers the measured number.
By their numbers in this assay, from the lowest: compound 1; then compounds 3 and 2 (each within the scatter of the next).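

In this assay, the exchange of 2,3-dihydro-1H-indol-1-yl for 6-methoxy-1,2,3,4-tetrahydroquinolin-1-yl gives a 1.0-fold lower number from compound 2 to compound 3 (0.01 log units; within the scatter) and so does not separate these two groups on a thiocarbonyl carbon. Against 4-acetylpiperazin-1-yl the new group gives a 17-fold higher number from compound 1 to compound 3 (1.23 log units; beyond the scatter) and thus compound 1 stands apart from both compound 2 and compound 3. No evidence on hand accounts for this result.

Still open, on these data alone, is whether the acetyl group or the piperazine ring carries the difference, which an unsubstituted piperazine or a morpholine on the thiocarbonyl carbon would address.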